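A few compounds are considered here, and "the series" means these few. Any claim that something is new, unique, unknown or untested is made for them only; others in the source may bear on it.

Measured so far in a functional assay on U-937 cells (Homo sapiens) for antiproliferative activity, read by CCK-8 assay, with a stated time of 24 h; on this read-out lower numbers stand for stronger inhibition and higher numbers for weaker inhibition:
- compound 1, `Cc1ccc(NC(=O)c2cccc(C(F)(F)F)c2)cc1-n1cc(-c2cnc3cccnn23)cn1` — compound 1 gives 13700 nM
- compound 2, `Cc1ccc(NC(=O)c2ccc(C(F)(F)F)cc2)cc1-n1cc(-c2cnc3cccnn23)cn1` — for compound 2 the assay reports only a limit, > 20000 nM
- compound 3, `Cc1ccc(NC(=O)c2ccc(CN3CCN(C)CC3)cc2)cc1-n1cc(-c2cnc3cccnn23)cn1` — compound 3 gives 10800 nM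

Compound 3 holds the lowest of the two numbers shown; the nearest is compound 1, which lies within the scatter of it. The value of compound 2 is a limit, not a number.

Compound 4, `CCc1ccc(C(=O)Nc2ccc(C)c(-n3cc(-c4cnc5cccnn45)cn3)c2)cc1`, differs from compound 3 by methyl in place of 4-methylpiperazin-1-yl on a saturated chain carbon bound to an aromatic carbon. Among the compounds with values here, the one measured step that touches this part of the molecule is an at least 1.8-fold lower number from compound 2 to compound 3 (0.26 log units; that floor lies within the scatter), in which the (4-methylpiperazin-1-yl)methyl group entered; that step is a floor only, because one end of it is the limit (the limit of > 20000 nM in this assay, at which 1 of the 3 values shown sits), and the floor lies within the scatter. The step of an at least 1.4-fold higher number from compound 1 to compound 2 (0.16 log units; that floor lies within the scatter) concerns only where the trifluoromethyl group sits and does not bear on this change. Compound 4 keeps the methyl of that group and drops the ring; undoing a step whose floor is within the scatter gives no ground for a change beyond the scatter, so the expected step of a 1.4-fold higher number from compound 3 to compound 4 (0.14 log units; within the scatter) is small, if anything toward a higher number. Compound 4 is therefore estimated at 15000 nM, with a range from 6000 nM to 40000 nM, the upper part of which reaches the assay limit.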

Compound 4, half-maximal inhibitory concentration: > 20000 nM
Compound 4: a limit, no number; the forecaster's own chance of this, stated with the estimate: 35%; middle value at least 1.3-fold (0.12 log units) away from the limit.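

Compound 4 gives a limit, > 20000 nM, not a number, in this assay. Replacing 4-methylpiperazin-1-yl with methyl on the saturated chain carbon bound to an aromatic carbon gives an at least 1.8-fold higher number from compound 3 to compound 4 (0.26 log units; that floor lies within the scatter), and the comparison with the 3-(trifluoromethyl)phenyl amide gives an at least 1.4-fold higher number from compound 1 to compound 4 (0.16 log units; that floor lies within the scatter); both are floors that point the same way, but neither shows a change beyond the scatter. Because compound 2 and compound 4 both rest at the limit, the step between them cannot be read, and the true size of the two floors remains unknown: the limit of > 20000 nM in this assay, at which 2 of the 4 values shown sit.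

The compounds shown leave open whether the difference from compound 3 requires the whole 4-methylpiperazin-1-yl ring or only an amine at this place, a question that a dimethylamino or morpholin-4-yl group on the same saturated chain carbon would address. They also leave open whether a longer chain, such as propyl, in place of the ethyl of compound 4 would give a number in this assay.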